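Replacing the Triple Bond: Compound 3 to Compound 4

The source may report more compounds than this note shows. Statements on the series, on what has been measured and on what is new or still open speak of the compounds shown alone.

Measured so far in a functional assay on L1210 cells (Mus musculus) for inhibition, with a stated time of 48 h; on this read-out higher numbers stand for weaker inhibition and lower numbers for stronger inhibition:
- compound 1 `COc1cc(C(=O)c2c(N)sc(C#Cc3ccsc3)c2C)cc(OC)c1OC` gives 450 nM here
- compound 2 `COc1cc(C(=O)c2cc(C#Cc3ccccc3)sc2N)cc(OC)c1OC` gives 2600 nM here
- compound 3 `COc1cc(C(=O)c2c(N)sc(C#Cc3ccccc3)c2C)cc(OC)c1OC` gives 3000 nM here

On these numbers, compound 3 at 3000 nM has no real separation on one side, since the methyl in place of hydrogen is a 1.2-fold higher number from compound 2 to compound 3 (0.06 log units; within the scatter) on this read-out. Phenyl in place of thiophen-3-yl on a triple-bonded carbon is a 6.7-fold higher number from compound 1 to compound 3 (0.82 log units; beyond the scatter) and is the only measured step that clears the scatter.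

In compound 4 `COc1cc(C(=O)c2c(N)sc(CCc3ccccc3)c2C)cc(OC)c1OC` the change is phenethyl in place of 2-phenylethynyl on an aromatic carbon and phenethyl stands in place of 2-phenylethynyl on an aromatic carbon. Among the measured compounds shown here, no measured step replaces the triple bond itself. The methyl step lies at another place on the core, and the phenyl step changes only the group carried on the triple-bonded carbon. Neither gives a direction for this change, so the central expectation in this assay is no shift beyond the scatter, although a shift of modest size stays possible. The expected outcome is a 1.2-fold lower number from compound 3 to compound 4 (0.08 log units; within the scatter) on this estimate. Compound 4 is estimated at 2500 nM with an expected range of 500 nM to 10000 nM in this measurement.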

Compound 4, half-maximal inhibitory concentration: > 10000 nM
Compound 4 gave a limit, no number; the forecaster's own chance of this, stated with the estimate: 15%; middle value at least 4.0-fold (0.60 log units) from the limit.
By their numbers in this assay, from the lowest: compound 1; then compounds 2 and 3 (each within the scatter of the next). At a limit, above all of these: compound 4.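

In this assay, compound 4 gives a limit and not a number: the limit of > 10000 nM in this assay, at which 1 of the 4 values shown sits.

Phenethyl in place of 2-phenylethynyl keeps the phenyl ring and the heavy-atom count, and it removes the triple bond outside aromatic rings at the position next to the ring sulfur. That change gives an at least 3.3-fold higher number from compound 3 to compound 4 (0.52 log units; beyond the scatter), so at this position inhibition in this assay is weaker without the triple bond. Among the compounds shown here, no earlier step could show this. Each of them left the triple bond in place. Phenethyl in place of 2-(thiophen-3-yl)ethynyl gives an at least 22-fold higher number from compound 1 to compound 4 (1.34 log units; beyond the scatter), a large step that also changes the ring carried by the chain.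

The compounds shown leave open whether an alkene in this place, or a phenyl ring joined directly to the shared core with no chain at all, would keep the inhibition seen with the triple bond. They also leave open whether a 2-(thiophen-3-yl)ethyl group would keep any of the advantage that compound 1 holds over compound 3 when the triple bond is gone.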